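Dropping one trifluoromethyl from a bis-trifluoromethyl anilide

The compounds below may be only part of what the source reports. "The series", "measured", "known", "first", "only" and "open" are said of these compounds alone.

Measured compounds:
- compound 1, `O=C1CCCCC1S(=O)(=O)Nc1cc(C(F)(F)F)ccc1C(F)(F)F`: 68.3%
- compound 2, `O=C1CCCCC1S(=O)(=O)Nc1cc(C(F)(F)F)cc(C(F)(F)F)c1`: 66.9%
- compound 3, `O=C1CCCCC1S(=O)(=O)Nc1ccccc1Cl`: 1.98%

All three share a cyclohexanone sulfonamide core joined to an aromatic ring; they differ only in what that ring carries. In a functional assay on Bel-7402 cells (Homo sapiens) for antiproliferative activity, read by sulforhodamine B assay, tested at 100 ug/mL (a higher number here means more inhibition at the concentration tested (going by the name of the read-out), a lower number less inhibition), compound 2 gives 66.9%, the second highest of the three numbers. Compound 1, with its trifluoromethyl groups arranged differently, gives 68.3%, a difference that lies within the usual scatter, so the two cannot be ordered. Compound 3, which carries chlorine rather than trifluoromethyl, gives 1.98%, far below compound 2 and well beyond the scatter.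

Compound 4, `O=C1CCCCC1S(=O)(=O)Nc1cccc(C(F)(F)F)c1`, has not yet been measured in this assay. It differs from compound 2 in one place: hydrogen in place of trifluoromethyl on an aromatic carbon. Within the data shown here, no measured pair shows exactly this change, so the step can only be judged from the whole set. The size of the step is expected to be a loss beyond the scatter, because compound 3 with no trifluoromethyl at all gives 1.98%, while both compounds that carry two trifluoromethyl groups sit high. For compound 4 the estimated value is 30%, with a likely range from 5% to 60%, which would mean an expected step of a number 36.9 percentage points lower from compound 2 to compound 4 (beyond the scatter).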

Compound 4, a percentage reported as inhibition, at one concentration (the size of the read-out at that concentration, not a potency): 11.4%
Estimate against measurement, compound 4: 18.6 percentage points above; measured number inside the range.
By their numbers in this assay, from the lowest: compounds 3 and 4 (each within the scatter of the next); then compounds 2 and 1 (each within the scatter of the next).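

The earlier compounds shown here all carried either two trifluoromethyl groups or none, so they could not show what a single trifluoromethyl does on its own. In this assay, replacing one trifluoromethyl with hydrogen gives a number 55.5 percentage points lower from compound 2 to compound 4 (beyond the scatter) and, starting from the other arrangement of the two groups, a number 56.9 percentage points lower from compound 1 to compound 4 (beyond the scatter), so one trifluoromethyl left on the ring is not enough to keep the high reading of either two-group compound. The two large steps point the same way, which suggests that the high readings depend on having a second group on the ring, although no measurement available here explains why.

Going by these compounds, what remains open is whether trifluoromethyl itself is needed on this aromatic carbon, or whether a smaller substituent such as a methyl group, a fluorine atom or a nitrile would retain much of the reading. On these data alone, it is also open how a larger group, such as a tert-butyl group, or a third trifluoromethyl on the same ring would behave.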